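The compounds below may be only part of what the source reports. "The series", "measured", "known", "first", "only" and "open" are said of these compounds alone.

Measured in an ADME assay on MDCK cells (Canis lupus familiaris) for cytotoxicity, read by MTT assay, with a stated time of 24 h; a lower number here means that less compound is tolerated, a higher number that more compound is tolerated:

- Compound 1 `Cc1cc(CNS(=O)(=O)c2ccc(C#N)cc2)c(C)o1`: 105000 nM
- Compound 2 `Cc1cc(CNS(=O)(=O)c2ccc([N+](=O)[O-])cc2)c(C)s1`: > 204000 nM
- Compound 3 `Cc1cc(CNS(=O)(=O)c2ccc(F)cc2)c(C)s1`: "not determined" (no result reported)

Compound 3 has no number to stand on, as its result reads "not determined" (no result reported). Compound 2 gives > 204000 nM, which is a limit of the assay and not a number. Among the measured compounds shown here, compound 1 gives 105000 nM, the only exact number so far.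

Compound 4 `Cc1cc(CNS(=O)(=O)c2ccc(Br)cc2)c(C)s1` is still unmeasured. The step bromo in place of fluoro on an aromatic carbon puts bromo in place of fluoro on an aromatic carbon. For the measured compounds named here, no measured pair shows the size of such a swap, so no step beyond the scatter is expected in this assay, in either direction. The expectation leans on compound 1 at 105000 nM. Compound 4 is expected near 130000 nM, with an estimated range of 50000 nM to 220000 nM.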

Compound 4, half-maximal cytotoxic concentration: 56400 nM
Beside the measured number, compound 4's estimate is 2.3-fold (0.36 log units) above it, and the stated range covers the measured number.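

At this place on the ring, para to a large group, this assay now shows that the choice of group can matter beyond the scatter: bromo in place of nitro gives an at least 3.6-fold lower number from compound 2 to compound 4 (0.55 log units; beyond the scatter). Compound 2 holds a limit of the assay and not a number: the limit of > 204000 nM in this assay, at which 1 of the 4 values shown sits.

The step from fluoro to bromo cannot be read, as compound 3 has no result. Still open, as far as these compounds go, is how an amine or a carboxylic acid at this place would compare with bromo, and whether the same swap behaves alike on a different core.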